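Moving the hydroxyl around one ring of a three-ring pyridine scaffold

The source may hold more compounds than are shown below. What is called first, only, known or untested is meant among the compounds shown, and "the series" means these compounds.

Compound 1 `Oc1ccccc1-c1cc(-c2ccccc2F)cc(-c2ccccc2O)n1`: in a functional assay on HCT-15 cells (Homo sapiens) for inhibition (a higher number here means a weaker inhibitor, a lower number a stronger inhibitor), compound 1 reaches only the limit > 50000 nM.
Compound 2 `Oc1cccc(-c2cc(-c3ccccc3F)cc(-c3ccccc3O)n2)c1`: compound 2 gives 8470 nM.
Compound 3 `Oc1cccc(-c2cc(-c3ccc(F)cc3)cc(-c3ccccc3O)n2)c1`: compound 3 reaches only the limit > 50000 nM.

For the measured compounds named here, compound 2 is the sole compound with a real number; the others sit at the limit (the limit of > 50000 nM in this assay, at which 2 of the 3 values shown sit). Compound 4 `Oc1ccc(-c2cc(-c3ccccc3F)cc(-c3ccccc3O)n2)cc1` differs from compound 2 by 4-hydroxyphenyl in place of 3-hydroxyphenyl on an aromatic carbon. Going by the values given here, two measured steps bear on this. Shifting the hydroxyl gave an at least 5.9-fold lower number from compound 1 to compound 2 (0.77 log units; beyond the scatter), and shifting the fluorine gave an at least 5.9-fold higher number from compound 2 to compound 3 (0.77 log units; beyond the scatter); both show that where a substituent sits on a ring changes the outcome strongly. The direction for a hydroxyl at the 4-position is not fixed by these data, so the expected step of a 2.4-fold higher number from compound 2 to compound 4 (0.37 log units; beyond the scatter) is uncertain and leans toward weaker inhibition. Compound 4 is estimated at 20000 nM, within 4000 nM to 50000 nM.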

Compound 4, half-maximal inhibitory concentration: > 50000 nM
Compound 4: a limit, no number (the forecaster's own chance of this, stated with the estimate: 40%); middle value at least 2.5-fold (0.39 log units) from the limit.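

Replacing the 3-hydroxyphenyl group with 4-hydroxyphenyl gives an at least 5.9-fold higher number from compound 2 to compound 4 (0.77 log units; beyond the scatter) in this assay. With this change, all three hydroxyl placings on this ring have been compared, and only the 3-hydroxyphenyl group of compound 2 gives a real number, while compound 1 and compound 4 both end at a limit. The step between those two limits cannot be read.

On these data alone, how an amine or a methoxy group would behave in place of this hydroxyl stays open. Any ranking among the weaker compounds also stays open, as most values are limits: the limit of > 50000 nM in this assay, at which 3 of the 4 values shown sit.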